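Dibromohydroxyphenyl hydrazone in an aryloxy urea series

The compounds below may be only part of what the source reports. "The series", "measured", "known", "first", "only" and "open" are said of these compounds alone.

Compound 1 `CN(C)CCn1cnnc1-c1cc(Oc2ccc(NC(=O)N/N=C/c3ccc(Cl)cc3Cl)cc2F)ccn1` gives 810 nM in a functional assay on A549 cells (Homo sapiens) for cytotoxicity, read by MTT assay, with a stated time of 72 h; a lower number here means a stronger inhibitor, a higher number a weaker inhibitor.
Compound 2 `CN(C)CCn1cnnc1-c1cc(Oc2ccc(NC(=O)N/N=C/c3ccc(O)c(Br)c3)cc2F)ccn1` gives 1370 nM in this assay.
Compound 3 `COc1cc(/C=N/NC(=O)Nc2ccc(Oc3ccnc(-c4nncn4CCN(C)C)c3)c(F)c2)cc(OC)c1OC` reaches only the assay limit, > 100000 nM, in this assay.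

Compound 1 holds the lower of the two actual numbers, with compound 2 close by: a 1.7-fold higher number from compound 1 to compound 2 (0.23 log units; within the scatter). Compound 3 sits at a limit rather than a number, (the limit of > 100000 nM in this assay, at which 1 of the 3 values shown sits). Compound 4 `CN(C)CCn1cnnc1-c1cc(Oc2ccc(NC(=O)N/N=C/c3cc(Br)c(O)c(Br)c3)cc2F)ccn1` differs from compound 1 by 3,5-dibromo-4-hydroxyphenyl in place of 2,4-dichlorophenyl on a carbon with a double bond to nitrogen. Among the compounds with values here, the step that bears most directly on this change is the one to compound 2, which stays within the scatter, since compound 4 likewise carries a halogenated hydroxyphenyl. The large steps of an at least 120-fold higher number from compound 1 to compound 3 (2.09 log units; beyond the scatter) and an at least 72-fold higher number from compound 2 to compound 3 (1.86 log units; beyond the scatter) concern the trimethoxyphenyl and say little here. Compound 4 is therefore expected to show no step beyond the scatter, a 1.2-fold higher number from compound 1 to compound 4 (0.07 log units; within the scatter). Compound 4 is estimated at 950 nM, with a range from 350 nM to 3000 nM.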

Compound 4, half-maximal inhibitory concentration: > 100000 nM
Compound 4 ended at the assay's limit (the forecaster's own chance of this, stated with the estimate: 5%); middle value at least 100-fold (2.02 log units) away from the limit.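

At this position, on a carbon with a double bond to nitrogen, a halogenated hydroxyphenyl does not by itself preserve activity: bromo in place of hydrogen on an aromatic carbon gives an at least 72-fold higher number from compound 2 to compound 4 (1.86 log units; beyond the scatter), and 3,5-dibromo-4-hydroxyphenyl in place of 2,4-dichlorophenyl gives an at least 120-fold higher number from compound 1 to compound 4 (2.09 log units; beyond the scatter). In this assay compound 4 stands at a limit rather than a number, as does compound 3: the limit of > 100000 nM in this assay, at which 2 of the 4 values shown sit.
The step between compound 3 and compound 4 cannot be read, as both are limits. Going by these compounds, how an amine or a carboxylic acid in place of the hydroxyl would behave remains open.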